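This account rests on a few compounds, and the source may have more. Where it says the series, first, only, none or still open, it means among the compounds named here.

Measured so far:
- compound 1, `CC/C=C/C(=O)Nc1cc2c(N3CCc4ccccc43)ncnc2cc1O[C@@H]1CCOC1`: 9590 nM in a functional assay on PC-3 cells (Homo sapiens) for antiproliferative activity, read by MTT assay, with a stated time of 72 h; on this read-out higher numbers stand for weaker inhibition and lower numbers for stronger inhibition
- compound 2, `CC/C=C/C(=O)Nc1cc2c(N3CCCc4ccccc43)ncnc2cc1O[C@@H]1CCOC1`: 14300 nM in this assay

Compound 1 holds the lower of the two numbers, but the step of a 1.5-fold higher number from compound 1 to compound 2 (0.17 log units; within the scatter) lies within the scatter, so no order between the two is claimed. Compound 3, `CCN(CC)C/C=C/C(=O)Nc1cc2c(N3CCc4ccccc43)ncnc2cc1O[C@@H]1CCOC1`, differs from compound 1 by diethylamino in place of methyl on a saturated chain carbon bound to a double-bonded chain carbon. Among the compounds with values here, the single measured step concerns a different part of the molecule and does not bear on this change; nothing measured predicts its size or direction. No step beyond the scatter is therefore expected in this assay. Compound 3 is estimated at 5000 nM (range 1000 nM to 25000 nM), expected as a 1.9-fold lower number from compound 1 to compound 3 (0.28 log units; within the scatter).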

Compound 3, half-maximal inhibitory concentration: 5780 nM
Beside the measured number, compound 3's estimate is 1.2-fold (0.06 log units) below it; measured number inside the range.
By their numbers in this assay, from the lowest: compounds 3, 1 and 2 (each within the scatter of the next, the first and the last beyond it).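

In this assay, within the data shown here, the step of a 1.7-fold lower number from compound 1 to compound 3 (0.22 log units; within the scatter) is the first reading at the saturated chain carbon bound to a double-bonded chain carbon. Diethylamino in place of methyl on this carbon therefore leaves the number within the scatter, so this larger amine-bearing chain end is accommodated without a readable shift. No measured evidence bears on this result.

Still open, as far as these compounds go, is whether a cyclic amine such as morpholine or piperidine on this carbon reads the same. Also open, from the compounds shown here alone, is whether diethylamino reads the same alongside 1,2,3,4-tetrahydroquinolin-1-yl on the aromatic carbon.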